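This account rests on a few compounds, and the source may have more. Where it says the series, first, only, none or still open, it means among the compounds named here.

Compound 2 `COc1cc(Cl)cc(-c2nn(-c3cccc(NC(=O)Nc4cccc(C(F)(F)F)c4)c3)cc2-c2ccncc2)c1` gives, in a functional assay on SR cells (Homo sapiens) for inhibition, read by sulforhodamine B assay, with a stated time of 48 h, tested at 0.1 uM (a higher number here means a weaker effect of the compound at the concentration tested, a lower number a stronger effect), 93%. Among the two measured compounds, compound 2 stands highest; its nearest neighbour, compound 1 `COc1cc(Cl)cc(-c2nn(-c3cccc(NC(=O)Nc4ccc(Cl)c(Cl)c4)c3)cc2-c2ccncc2)c1`, gives in this assay 51%. Going by the values given here, the one measured step runs a number 42 percentage points higher from compound 1 to compound 2 (beyond the scatter), where 3-(trifluoromethyl)phenyl replaces 3,4-dichlorophenyl on an amide-type nitrogen.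

Compound 3 `COc1cc(Cl)cc(-c2nn(-c3cccc(NC(=O)c4cccc(C(F)(F)F)c4)c3)cc2-c2ccncc2)c1` is not yet measured. It differs from compound 2 as follows: 3-(trifluoromethyl)phenyl in place of (3-(trifluoromethyl)phenyl)amino on a carbonyl carbon. The carbonyl carbon of compound 2 thus carries 3-(trifluoromethyl)phenyl in compound 3 rather than (3-(trifluoromethyl)phenyl)amino, the one hydrogen-bond donor of that group being lost.

Among the compounds with values here, no measured step bears on this change: the step from compound 1 to compound 2 concerns the aryl group on the amide-type nitrogen, not the link from the carbonyl carbon to it. Within the data shown here, since the only measured step, large as it is, does not touch the carbonyl carbon, no step beyond the scatter is expected in this assay for compound 3, though the uncertainty is wide. For compound 3 the expected outcome in this assay is 90%, with a range from 68% to 105%, which is expected to amount to a number 3 percentage points lower from compound 2 to compound 3 (within the scatter).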

Compound 3, a percentage reported as activity, at one concentration (the size of the read-out at that concentration, not a potency): 54%
Compound 3: middle estimate off by 36 percentage points, on the high side; the measured number lies below the stated range.
By their numbers in this assay, from the lowest: compounds 1 and 3 (each within the scatter of the next); then compound 2.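

In this assay, the link at the carbonyl carbon proves to matter as much as the aryl group: with the 3-(trifluoromethyl)phenyl ring kept, removing the amino nitrogen gives a number 39 percentage points lower from compound 2 to compound 3 (beyond the scatter), which here means a stronger effect at the concentration tested. Placing 3-(trifluoromethyl)phenyl on the carbonyl carbon in place of (3,4-dichlorophenyl)amino gives a number 3 percentage points higher from compound 1 to compound 3 (within the scatter), so the weak effect of compound 2 is set apart from both neighbours by a change at either of two points in this group. Nothing available explains why this change has so large an effect.

The compounds shown leave open whether the amide hydrogen or the nitrogen atom as such is what counts, a question that a methylene group or a methylated nitrogen in the link could address. They also leave open how 3,4-dichlorophenyl would read when attached directly to the carbonyl carbon, and so whether the two aryl groups differ in the same way with and without the amino nitrogen.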